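Chain length and aryl amide swap in the thiazolo series

A few compounds are considered here, and "the series" means these few. Any claim that something is new, unique, unknown or untested is made for them only; others in the source may bear on it.

Measured compounds:
- compound 1 `O=S(=O)(NCCCNc1nccc(-c2c(-c3cccc(F)c3)nc3sccn23)n1)c1ccc(F)cc1` — > 20000 nM
- compound 2 `O=C(NCCNc1nccc(-c2c(-c3cccc(F)c3)nc3sccn23)n1)c1ccc(Cl)cc1` — 8160 nM
- compound 3 `O=C(NCCCNc1nccc(-c2c(-c3cccc(F)c3)nc3sccn23)n1)c1ccc(Cl)cc1` — > 20000 nM

In a functional assay on SK-MEL-28 cells (Homo sapiens) for cytotoxicity, read by MTT assay (a lower number here means a stronger inhibitor, a higher number a weaker inhibitor), compound 3 sits only at a limit; its value > 20000 nM is a limit of the assay, not a number, and the limit of > 20000 nM in this assay, at which 2 of the 3 values shown sit, applies. Compound 2 in this assay gives 8160 nM, and the step of an at least 2.4-fold higher number from compound 2 to compound 3 (0.38 log units; beyond the scatter) shows that lengthening the chain costs activity. Compound 4 `Cc1ccc(C(=O)NCCNc2nccc(-c3c(-c4cccc(F)c4)nc4sccn34)n2)cc1` makes the change ((4-methylphenyl)carbonyl)amino in place of (((4-chlorophenyl)carbonyl)amino)methyl on a saturated chain carbon, two bonds along the chain from a nitrogen on an aromatic ring: the chain returns to the length of compound 2, while the aryl ring carries a methyl rather than a chlorine. Reversing the chain lengthening is expected to recover activity, and the step of an at least 2.5-fold lower number from compound 3 to compound 4 (0.39 log units; beyond the scatter) is estimated accordingly. Compound 4 is therefore expected near 8000 nM, within 3000 nM to 20000 nM.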

Compound 4, half-maximal inhibitory concentration: 18800 nM
Compound 4: the middle estimate sits 2.4-fold (0.37 log units) below what was measured; the range from low to high includes it.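

In this assay on the shorter chain, methyl in place of chloro on an aromatic carbon gives a 2.3-fold higher number from compound 2 to compound 4 (0.36 log units; beyond the scatter) and so compound 4 is the weaker inhibitor of the two. Only floors are given by an at least 1.0-fold lower number from compound 3 to compound 4 (0.02 log units; that floor lies within the scatter) and by an at least 1.0-fold lower number from compound 1 to compound 4 (0.02 log units; that floor lies within the scatter) and both floors lie within the scatter. These two steps stay floors because compound 1 and compound 3 each sit at a limit: the limit of > 20000 nM in this assay, at which 2 of the 4 values shown sit.

From the compounds shown here alone, it remains open how an amine or a carboxylic acid in place of chloro on that aromatic carbon compares with compound 2. Going by these compounds, a chain longer than that of compound 3 also remains open.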